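Swapping the para substituent on the aryl ring of a spiro core

A few compounds are considered here, and "the series" means these few. Any claim that something is new, unique, unknown or untested is made for them only; others in the source may bear on it.

Measured so far:
compound 1, `CN(C)c1ccc(N2C(=O)NC3(CSC4=C3C(=O)c3ncccc3C4=O)C2=O)cc1`: 20 nM
compound 2, `COc1ccc(N2C(=O)NC3(CSC4=C3C(=O)c3ncccc3C4=O)C2=O)cc1`: 2 nM

In a functional assay on HT-29 cells (Homo sapiens) for antiproliferative activity, read by MTT assay, with a stated time of 96 h (on this read-out higher numbers stand for weaker inhibition and lower numbers for stronger inhibition), compound 1 gives 20 nM, the highest of the two numbers shown, while compound 2 gives 2 nM. Within the data shown here, the one measured step, a 10-fold lower number from compound 1 to compound 2 (1.00 log units; beyond the scatter), replaces the dimethylamino group with a methoxy group on the aromatic carbon and lies beyond the scatter.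

Compound 3, `CCc1ccc(N2C(=O)NC3(CSC4=C3C(=O)c3ncccc3C4=O)C2=O)cc1`, has not yet been measured. It differs from compound 1 by ethyl in place of dimethylamino on an aromatic carbon, at the place described as an aromatic carbon of a six-membered carbon-only ring, para to a large group. Among the measured compounds shown here, the only step that bears on this change is the one from compound 1 to compound 2, since it removes the same dimethylamino group; it gave a lower number. Because a 10-fold lower number from compound 1 to compound 2 (1.00 log units; beyond the scatter) showed that losing dimethylamino need not cost potency, a lower number is expected for compound 3, though ethyl is not methoxy, so a smaller step, a 2.0-fold lower number from compound 1 to compound 3 (0.30 log units; within the scatter), is estimated. The expected value for compound 3 is 10 nM, in the range 3 nM to 40 nM.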

Compound 3, half-maximal inhibitory concentration: 1 nM
Estimate against measurement, compound 3: 10-fold (1.00 log units) above; measured number outside the range, below it.
By their numbers in this assay, from the lowest: compounds 3 and 2 (each within the scatter of the next); then compound 1.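

The drop in the number on leaving dimethylamino does not depend on an oxygen-bearing replacement: in this assay, ethyl, made of carbon only, gives a 20-fold lower number from compound 1 to compound 3 (1.30 log units; beyond the scatter). Set against methoxy, ethyl gives a 2.0-fold lower number from compound 2 to compound 3 (0.30 log units; within the scatter), so these two groups cannot be told apart here, and among the three compounds, only compound 1, with dimethylamino, stands apart from the others. No measurement at hand explains why dimethylamino gives the higher number.

The compounds shown leave open how a longer chain such as butyl, a chlorine atom or a carboxylic acid would fare at this place on the aromatic ring. They also leave open whether a plain amine would behave like dimethylamino or like ethyl and methoxy.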